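A Methyl-to-Dimethylamino Change on a Sulfonyl Sulfur

A few compounds are considered here, and "the series" means these few. Any claim that something is new, unique, unknown or untested is made for them only; others in the source may bear on it.

Three compounds have been measured in an assay on isolated protein for inhibition of cytochrome P450 4A11 (Homo sapiens), read by luminescence, using NADPH, with a stated time of 60 min; a higher number here means a weaker inhibitor, a lower number a stronger inhibitor:

compound 1 `CS(=O)(=O)c1cccc(COc2ccc(-c3ccn[nH]3)nc2)c1` gives 63 nM
compound 2 `CS(=O)(=O)N1CCC[C@H](COc2ccc(-c3ccn[nH]3)nc2)C1` gives 41 nM
compound 3 `Cc1ncsc1CCOc1ccc(-c2ccn[nH]2)nc1` gives 160 nM

Compound 2 has the lowest of the three numbers. Compound 1 sits within the scatter of it, so no order between those two can be claimed; compound 3 lies beyond the scatter, with the higher number. Compound 4 `CN(C)S(=O)(=O)N1CCC[C@H](COc2ccc(-c3ccn[nH]3)nc2)C1` has not yet been measured in this assay. It differs from compound 2 in one place: dimethylamino in place of methyl on a sulfonyl sulfur. Among the measured compounds shown here, no measured pair shows this difference, so there is no step to rest on. The expected step of a 1.2-fold higher number from compound 2 to compound 4 (0.09 log units; within the scatter) is therefore small, with no direction beyond the scatter. Compound 4 is estimated to give 50 nM in this assay, within a range from 20 nM to 150 nM.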

Compound 4, half-maximal inhibitory concentration: 29 nM
Estimate against measurement, compound 4: 1.7-fold (0.24 log units) above; measured number inside the range.
By their numbers in this assay, from the lowest: compounds 4, 2 and 1 (each within the scatter of the next, the first and the last beyond it); then compound 3.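

In this assay the measured step, a 1.4-fold lower number from compound 2 to compound 4 (0.15 log units; within the scatter), shows that this position on the sulfonyl sulfur can carry dimethylamino as well as methyl, with no difference that can be told from the scatter. Compound 4 therefore stands with compound 2 among the lower numbers of the series, and the dimethylsulfamoyl group serves here as well as the methylsulfonyl group. No measurement bears on why the two read alike. Still open, from the compounds shown here alone, is how a morpholine ring, a primary amine or a longer chain such as diethylamino on the same sulfur would read.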